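Replacing the Amide Tail of Compound 2

A few compounds are considered here, and "the series" means these few. Any claim that something is new, unique, unknown or untested is made for them only; others in the source may bear on it.

compound 1 `CCCCCN(CCCCC)C(=O)[C@H]1CCN(C(=O)N(c2ccccc2)c2ccccc2)[C@H](C(=O)NCCNCC(N)=O)C1`: 13 nM
compound 2 `CCCCCN(CCCCC)C(=O)[C@H]1CCN(C(=O)N(c2ccccc2)c2cccc(Cl)c2)[C@H](C(=O)NCCNCC(N)=O)C1`: 3.5 nM

Within the data shown here, in an assay on CHO cells for binding affinity to Substance-P receptor (Homo sapiens) (a lower number here means a stronger inhibitor, a higher number a weaker inhibitor), compound 2 gives 3.5 nM, the lowest of the two numbers known. Its nearest neighbour is compound 1, which in this assay gives 13 nM; the step of a 3.7-fold lower number from compound 1 to compound 2 (0.57 log units; beyond the scatter) lies beyond the scatter. Compound 3 `CCCCCN(CCCCC)C(=O)[C@H]1CCN(C(=O)N(c2ccccc2)c2cccc(Cl)c2)[C@H](C(=O)NCCN(C)Cc2ccccc2OC)C1` differs from compound 2 in another place altogether: (2-methoxybenzyl)(methyl)amino in place of (carbamoylmethyl)amino on a saturated chain carbon, two bonds along the chain from an amide-type nitrogen. Among the measured compounds shown here, no measured step bears on this change, since the single step at hand concerns a chloro in place of hydrogen on an aromatic carbon, far from the chain that is altered here. With nothing to anchor the size or direction, the expectation stays close to compound 2 with a wide range. Compound 3 is expected to give about 2.5 nM in this assay, between 0.4 nM and 15 nM. The expected step is a 1.4-fold lower number from compound 2 to compound 3 (0.15 log units; within the scatter), an estimate rather than a measurement.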

Compound 3, half-maximal inhibitory concentration: 1.4 nM
The estimate for compound 3 lay 1.8-fold (0.25 log units) above the measured number, and the stated range covers the measured number.
By their numbers in this assay, from the lowest: compound 3; then compound 2; then compound 1.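

The far end of the amide tail, identical in compound 1 and compound 2, proves open to a large exchange: in this assay, replacing (carbamoylmethyl)amino with (2-methoxybenzyl)(methyl)amino gives a 2.5-fold lower number from compound 2 to compound 3 (0.40 log units; beyond the scatter). The group that enters carries a six-membered aromatic ring of carbon only and no hydrogen-bond donors, whereas the group that leaves has two, so in this pair those donors are not needed for the number to fall. Nothing available explains why this exchange lowers the number.

Among these compounds, the single exchange leaves open which part of the new group accounts for the step: the methyl on the nitrogen, the aromatic ring or the methoxy group. A plain benzyl group, or a 2-methoxybenzyl group on a nitrogen without the methyl, would help to separate these contributions.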